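Trading pyridin-3-yl for phenyl on compound 3

The compounds below may be only part of what the source reports. "The series", "measured", "known", "first", "only" and "open" are said of these compounds alone.

Of the compounds shown here, three have been tested so far in an ADME assay on HepG2 2.2.15 cells (Homo sapiens) for cytotoxicity, read by MTT assay; a lower number here means that less compound is tolerated, a higher number that more compound is tolerated. Here, compound 1 `C=C1CC[C@@H]2[C@](C)(COC(=O)c3cc(=O)c4ccccc4o3)[C@H](O)CC[C@@]2(C)[C@@H]1/C=C/C1=CCOC1=O` gives 171000 nM. Compound 3 `C=C1CC[C@@H]2[C@](C)(CO)[C@H](OC(=O)c3cccnc3)CC[C@@]2(C)[C@@H]1C/C=C1\C=COC1=O` gives 337000 nM, and this number lies within the usual scatter of the number for compound 1, so the two cannot be told apart. Compound 2 `C=C1CC[C@@H]2[C@](C)(COC(=O)c3cccnc3)[C@H](OC(=O)c3cccnc3)CC[C@@]2(C)[C@@H]1/C=C/C1=CCOC1=O` has no exact number, only a limit of > 1910000 nM.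

The next compound, compound 4 `C=C1CC[C@@H]2[C@](C)(CO)[C@H](OC(=O)c3ccccc3)CC[C@@]2(C)[C@@H]1C/C=C1\C=COC1=O`, has phenyl in place of pyridin-3-yl on a carbonyl carbon. Read one bond further out, (pyridin-3-yl)carbonyl becomes benzoyl. An aromatic ring with a hetero atom thus gives way to one of carbon only.

For the measured compounds named here, no two tested compounds differ in just one place, so no measured step can serve as a guide. Compound 1 at 171000 nM and compound 3 at 337000 nM carry different aromatic groups and still sit close together, which suggests a modest effect from this swap. Compound 2, however, stands apart with its limit. The estimated change is a 1.4-fold lower number from compound 3 to compound 4 (0.15 log units; within the scatter), a slight drift towards a lower number that is expected to stay within the scatter. For compound 4 the expected value is 240000 nM, with an estimated range from 100000 nM to 600000 nM.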

Compound 4, half-maximal cytotoxic concentration: 103000 nM
Compound 4: middle estimate off by 2.3-fold (0.37 log units), on the high side; the measured number falls inside the stated range.
By their numbers in this assay, from the lowest: compounds 4, 1 and 3 (each within the scatter of the next, the first and the last beyond it). At a limit, above all of these: compound 2.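

For the compounds shown here, compounds 3 and 4 are the first tested pair that differ in only one place, so a single change can now be read directly in this assay and does not have to be inferred from compounds that differ in several places. Placing phenyl in place of pyridin-3-yl on this carbonyl carbon gives a 3.3-fold lower number from compound 3 to compound 4 (0.51 log units; beyond the scatter), and this step lies beyond the scatter, showing that replacing an aromatic ring containing one nitrogen with a ring of carbon only is enough to lower the tolerated concentration in this series. Nothing among the values shown says why the number moves.

The compounds shown leave open how other groups on this carbonyl carbon would behave, such as a simple methyl group, a saturated cyclohexyl ring, or a phenyl ring carrying an amine. Going by these compounds alone, they also leave open whether the same swap gives a similar step on a differently built compound, as this single pair is the only direct comparison available so far.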